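Oxazole ketones: phenyl carbinol tail in place of pyridyl

The source may report more compounds than this note shows. Statements on the series, on what has been measured and on what is new or still open speak of the compounds shown alone.

Measured compounds:
compound 1 `O=C(CCCCCCc1cccnc1)c1ncc(-c2ccccn2)o1` — 32 nM
compound 2 `O=C(CCCCSCc1ccccc1)c1ncc(-c2ccccn2)o1` — 25 nM

In an assay for inhibition of Fatty-acid amide hydrolase 1 (Rattus norvegicus) (a lower number here means a stronger inhibitor, a higher number a weaker inhibitor), compound 1 gives 32 nM; compound 2 gives 25 nM, and the step of a 1.3-fold lower number from compound 1 to compound 2 (0.11 log units; within the scatter) leaves the two indistinguishable. Compound 3 `O=C(CCCCCC(O)c1ccccc1)c1ncc(-c2ccccn2)o1` has not yet been measured. It differs from compound 1 as follows: hydroxy(phenyl)methyl in place of (pyridin-3-yl)methyl on a saturated chain carbon, five bonds along the chain from a carbonyl carbon. Within the data shown here, the only step measured so far, the change of tail a 1.3-fold lower number from compound 1 to compound 2 (0.11 log units; within the scatter), also swapped the aromatic end of the chain and moved nothing beyond the scatter. The tail exchange in compound 3 is expected to behave alike, so the estimated step of a 1.1-fold higher number from compound 1 to compound 3 (0.04 log units; within the scatter) is close to none. Compound 3 is therefore estimated at 35 nM, expected within 12 nM to 100 nM.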

Compound 3, inhibition constant: 35 nM
Estimate against measurement, compound 3: no gap at the digits printed; the range from low to high includes it.
By their numbers in this assay, from the lowest: compounds 2, 1 and 3 (each within the scatter of the next).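

In this assay, the change at this chain carbon brings a hydrogen-bond donor into the tail and removes the ring nitrogen, yet the step stays within the scatter (a 1.1-fold higher number from compound 1 to compound 3 (0.04 log units; within the scatter)). Compound 1 and compound 2 showed no such change, as neither carries a hydrogen-bond donor in the tail. No measurement shown explains why the donor and the loss of the ring nitrogen leave the number within the scatter.

Open, from the compounds shown here alone, is whether a methoxy group or an amine in place of the hydroxy group of compound 3 would also stay within the scatter of compound 1.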